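Replacing 4-chlorophenyl with 2-methoxyphenyl on a shared core

The source may report more compounds than this note shows. Statements on the series, on what has been measured and on what is new or still open speak of the compounds shown alone.

In a functional assay on HL-60 cells (Homo sapiens) for antiproliferative activity, read by MTT assay, with a stated time of 72 h (a higher number here means a weaker inhibitor, a lower number a stronger inhibitor), compound 1 (`COc1cc(-n2ncnc2-c2ccc(Cl)cc2)cc(OC)c1OC`) gives > 10000 nM as its reading, which is a limit of the assay and not a number. Compound 1 stands at the limit of > 10000 nM in this assay, at which 1 of the 3 values shown sits, in this small set.

Two close relatives give real numbers: compound 2 (`CCOc1ccc(-c2ncnn2-c2cc(OC)c(OC)c(OC)c2)cc1`) reads 20 nM in this assay and compound 3 (`COc1cc(-n2ncnc2-c2ccc(OC(C)C)cc2)cc(OC)c1OC`) reads 700 nM there. Ethoxy in place of chloro gives an at least 500-fold lower number from compound 1 to compound 2 (2.69 log units; beyond the scatter) and isopropoxy in place of chloro gives an at least 14-fold lower number from compound 1 to compound 3 (1.15 log units; beyond the scatter) in the same test. Adding methyl to the ethoxy chain gives a 35-fold higher number from compound 2 to compound 3 (1.54 log units; beyond the scatter) so a single small edit can move these numbers a long way.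

Compound 4 (`COc1ccccc1-c1ncnn1-c1cc(OC)c(OC)c(OC)c1`) carries 2-methoxyphenyl in place of 4-chlorophenyl on an aromatic carbon and otherwise keeps the core of compound 1. Neither compound 2 nor compound 3 carries a 2-methoxyphenyl group, so these steps guide the forecast only loosely.

Going by compound 3 with its an at least 14-fold lower number from compound 1 to compound 3 (1.15 log units; beyond the scatter) as the closer guide, a large move to a lower number is still expected. The estimated change is an at least 12-fold lower number from compound 1 to compound 4 (1.09 log units; beyond the scatter) with wide uncertainty. For compound 4 the estimated value is 800 nM with 100 nM to 6000 nM as the expected range.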

Compound 4, half-maximal inhibitory concentration: > 10000 nM
Compound 4: no number, only a limit; the forecaster's own chance of this, stated with the estimate: 10%; middle value at least 12-fold (1.09 log units) from the limit.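

In this assay compound 4 gives > 10000 nM, which is a limit of the assay and not a number. Going by these compounds alone, compound 1 and compound 4 both stand at this limit, so no step between them can be read: the limit of > 10000 nM in this assay, at which 2 of the 4 values shown sit. The compounds shown leave open whether 2-methoxyphenyl and 4-chlorophenyl differ at all on the shared core.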